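Phenyl ring substitution in the triazole series: compound 4

This account rests on a few compounds, and the source may have more. Where it says the series, first, only, none or still open, it means among the compounds named here.

Compound 2 `CC1(C)[C@H]2CC[C@]1(C)N(Cc1cn(-c3ccccc3C#N)nn1)C(=O)C2` in a functional assay on LoVo cells (Homo sapiens) for inhibition, read by MTT assay, with a stated time of 24 h (on this read-out lower numbers stand for stronger inhibition and higher numbers for weaker inhibition), gives 140 nM, the second highest of the measured numbers. Compound 1 `CC1(C)[C@H]2CC[C@]1(C)N(Cc1cn(-c3cccc(F)c3)nn1)C(=O)C2` gives 90 nM in this assay, and compound 3 `CC1(C)[C@H]2CC[C@]1(C)N(Cc1cn(-c3cccc(C#N)c3)nn1)C(=O)C2` gives 320 nM. The measured steps are all modest: a 1.6-fold higher number from compound 1 to compound 2 (0.19 log units; within the scatter), a 2.3-fold higher number from compound 2 to compound 3 (0.36 log units; beyond the scatter), and a 3.6-fold higher number from compound 1 to compound 3 (0.55 log units; beyond the scatter). Compound 4 `CC1(C)[C@H]2CC[C@]1(C)N(Cc1cn(-c3ccccc3)nn1)C(=O)C2` carries the change (hydrogen in place of cyano on an aromatic carbon). Going by the values given here, no measured step removes a ring substituent outright; the steps that bear on it exchange one substituent for another and stay within a narrow span. The expectation in this assay is therefore a step of a 1.1-fold higher number from compound 2 to compound 4 (0.03 log units; within the scatter), not clearly beyond the scatter in either direction. Compound 4 is estimated at 150 nM in this assay, with a range of 50 nM to 450 nM.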

Compound 4, half-maximal inhibitory concentration: 50 nM
Beside the measured number, compound 4's estimate is 3.0-fold (0.48 log units) above it; measured number inside the range.
By their numbers in this assay, from the lowest: compounds 4, 1 and 2 (each within the scatter of the next, the first and the last beyond it); then compound 3.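

In this assay, the change gives the first direct read on removing a ring substituent. Hydrogen in place of cyano gives a 2.8-fold lower number from compound 2 to compound 4 (0.45 log units; beyond the scatter) and a 6.4-fold lower number from compound 3 to compound 4 (0.81 log units; beyond the scatter), so both cyano compounds give higher numbers than the unsubstituted phenyl, while hydrogen in place of fluoro gives a 1.8-fold lower number from compound 1 to compound 4 (0.26 log units; within the scatter), which leaves those two compounds unseparated. No evidence at hand bears on these steps. From the compounds shown here alone, whether any substituent on this phenyl ring can give a number clearly lower than compound 4 remains open, for example an amine, a carboxylic acid or a methoxy group.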